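A few compounds are considered here, and "the series" means these few. Any claim that something is new, unique, unknown or untested is made for them only; others in the source may bear on it.

Measured in a functional assay on RAW264.7 cells (Mus musculus), read by fluorescence; a higher number here means a weaker inhibitor, a lower number a stronger inhibitor:
- Compound 1 `CCOC(=O)C1=CCCCC1S(=O)(=O)Cc1ccccc1F`: 97 nM
- Compound 2 `CCOC(=O)C1=CCCCC1S(=O)(=O)Cc1cccc(Cl)c1F`: 12 nM

Of these two compounds, compound 1 stands at the higher number, 97 nM, and is therefore the weaker inhibitor of the pair. Among the compounds with values here, the only measured step is an 8.1-fold lower number from compound 1 to compound 2 (0.91 log units; beyond the scatter), which came with chloro in place of hydrogen on an aromatic carbon.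

Compound 3 `CCOC(=O)C1=CCCCC1S(=O)(=O)Cc1ccncc1` has not yet been measured. It differs from compound 1 in one place: pyridin-4-yl in place of 2-fluorophenyl on a saturated chain carbon bound to a sulfonyl sulfur. Here the whole aromatic group is exchanged, and no measured step covers such an exchange directly. The nearest evidence is an 8.1-fold lower number from compound 1 to compound 2 (0.91 log units; beyond the scatter), which shows that a single change on this aromatic group can move the number in this assay beyond the scatter. That step added a halogen and lowered the number, whereas compound 3 carries no halogen, so a higher number is expected, though with little certainty. The expected step is a 5.2-fold higher number from compound 1 to compound 3 (0.71 log units; beyond the scatter), similar in size to the measured one but opposite in direction. For compound 3 the estimate is 500 nM, with an expected range of 120 nM to 2500 nM.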

Compound 3, half-maximal inhibitory concentration: 1410 nM
For compound 3 the middle estimate is 2.8-fold (0.45 log units) below the measured one; the measured number falls inside the stated range.
By their numbers in this assay, from the lowest: compound 2; then compound 1; then compound 3.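

In this assay, exchanging the whole aromatic group on the saturated chain carbon bound to a sulfonyl sulfur gives a 15-fold higher number from compound 1 to compound 3 (1.16 log units; beyond the scatter), so this position responds to replacement of the 2-fluorophenyl group and not only to a substituent added to it, as in an 8.1-fold lower number from compound 1 to compound 2 (0.91 log units; beyond the scatter). Read from compound 1, the two steps run in opposite directions: adding chloro goes with a stronger inhibitor, and pyridin-4-yl, which removes the fluorine and brings a ring nitrogen with a hydrogen-bond acceptor, goes with a weaker one. No measurement at hand explains the rise in the number with this exchange.

The exchange alters the fluorine and the ring nitrogen together, and the compounds shown do not separate the two: an unsubstituted phenyl group would speak to the fluorine, and pyridin-3-yl or pyridin-2-yl to where the ring nitrogen is tolerated. They also leave open whether chloro would lower the number on the pyridine ring as it does on the 2-fluorophenyl group, and how a carboxylic acid in place of the ethyl ester would read.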